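This account rests on a few compounds, and the source may have more. Where it says the series, first, only, none or still open, it means among the compounds named here.

Measured compounds:
- compound 1 `Nc1scc(CN2CCN(c3ccc(Cl)cc3Cl)CC2)c1C(=O)c1ccc(Cl)cc1`: -54%
- compound 2 `Nc1scc(CN2CCN(c3cccc(Cl)c3Cl)CC2)c1C(=O)c1ccc(Cl)cc1`: -57%
- compound 3 `Nc1scc(CN2CCN(c3ccc(F)c(F)c3)CC2)c1C(=O)c1ccc(Cl)cc1`: -78%

In a functional assay on CHO cells with adenosine receptor A1 (Homo sapiens) as the target, read by cAMP accumulation and immunoassay, with a stated time of 6 min, tested at 1 uM (on this read-out lower numbers stand for a stronger effect and higher numbers for a weaker effect at the one concentration tested), compound 2 gives -57%, the second highest of the three numbers. Its nearest neighbour is compound 1, with a number 3 percentage points lower from compound 1 to compound 2 (within the scatter), so the two cannot be told apart on this read-out. Compound 3 stands furthest off, with a number 21 percentage points lower from compound 2 to compound 3 (beyond the scatter).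

Compound 4 `Nc1scc(CN2CCN(c3cccc(F)c3F)CC2)c1C(=O)c1ccc(Cl)cc1` is not yet measured in this assay. It differs from compound 2 in one place: 2,3-difluorophenyl in place of 2,3-dichlorophenyl on an amine nitrogen in a ring.

For the measured compounds named here, two measured steps bear on this change, both of which also swap the pair of chlorines for a pair of fluorines, though at different ring positions: a number 24 percentage points lower from compound 1 to compound 3 (beyond the scatter) and a number 21 percentage points lower from compound 2 to compound 3 (beyond the scatter). Since the position change alone, a number 3 percentage points lower from compound 1 to compound 2 (within the scatter), sits within the scatter, most of those two steps is taken to come from the halogen swap. A modest step downward in this assay is therefore expected from compound 2 to compound 4, in the direction of compound 3.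

The expected step is a number 15 percentage points lower from compound 2 to compound 4 (beyond the scatter). Compound 4 is estimated to give -72% in this assay, with a range from -86% to -58%.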

Compound 4, a percentage reported as activity, at one concentration (the size of the read-out at that concentration, not a potency): -66%
Compound 4: middle estimate off by 6 percentage points, on the low side; measured number inside the range.
By their numbers in this assay, from the lowest: compound 3; then compounds 4, 2 and 1 (each within the scatter of the next, the first and the last beyond it).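

In this assay, for the compounds shown here, the pair of chlorines is exchanged for a pair of fluorines with the ring pattern held for the first time, and this gives a number 9 percentage points lower from compound 2 to compound 4 (within the scatter); the earlier halogen steps all carried a change of pattern as well, so the exchange on its own does not separate from the noise here. With fluorine held, the pattern change on the ring attached to the amine nitrogen gives a number 12 percentage points higher from compound 3 to compound 4 (beyond the scatter), whereas the only pattern change among the chlorine compounds gave a number 3 percentage points lower from compound 1 to compound 2 (within the scatter), so among these four compounds the pattern counts for more in the difluorophenyl pair than in the dichlorophenyl pair. The step that changes both halogen and pattern, a number 12 percentage points lower from compound 1 to compound 4 (beyond the scatter), is smaller than either earlier step into compound 3, so much of what those steps seemed to credit to the halogen exchange belongs to the 3,4-difluorophenyl group in particular.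

No measurement at hand accounts for these differences. Open, going by these compounds, is how 2,4-difluorophenyl would read, which would complete the halogen pairs, and how a methoxy group, a nitrile or a single fluorine on this phenyl ring would compare.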